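The source may report more compounds than this note shows. Statements on the series, on what has been measured and on what is new or still open speak of the compounds shown alone.

Two compounds with a shared core were tested in an assay for inhibition of high affinity nerve growth factor receptor (Homo sapiens), read by HTRF, with a stated time of 30 min, in the presence of a further agent that is not named here; a lower number here means a stronger inhibitor, a higher number a weaker inhibitor. Compound 1 `Cc1cc(Nc2nc(NCc3cc(F)ccc3F)nc3ccccc23)n[nH]1` gives 7.5 nM in this assay. Compound 2 `Cc1cc(Nc2nc(NCc3c(F)cccc3F)nc3ccccc23)n[nH]1` gives 160 nM in this assay, the highest of the two numbers; its nearest neighbour is compound 1, and the step of a 21-fold higher number from compound 1 to compound 2 (1.33 log units; beyond the scatter) is the only one available, a large move from a change confined to where the two fluorines sit on the phenyl ring.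

Compound 3 `Cc1cc(Nc2nc(NCc3cc(F)c(F)c(F)c3)nc3ccccc23)n[nH]1` has not yet been measured. Its change from compound 2 is 3,4,5-trifluorophenyl in place of 2,6-difluorophenyl on a saturated chain carbon bound to a nitrogen on an aromatic ring. Among the compounds with values here, no measured step covers this change directly; the step from compound 1 to compound 2 shows only that shifting fluorines around this ring can move the number a long way in either direction, so the sign of the step to compound 3 cannot be read from it, and the expectation is correspondingly wide. Compound 3 is estimated to sit between the two measured neighbours, with an expected step of a 4.0-fold lower number from compound 2 to compound 3 (0.60 log units; beyond the scatter) in this assay. The estimate for compound 3 is 40 nM, with a range from 8 nM to 250 nM.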

Compound 3, half-maximal inhibitory concentration: 870 nM
Beside the measured number, compound 3's estimate is 22-fold (1.34 log units) below it, and the stated range ends below it.
By their numbers in this assay, from the lowest: compound 1; then compound 2; then compound 3.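

At this position on a saturated chain carbon bound to a nitrogen on an aromatic ring, the 3,4,5-trifluorophenyl group gives a further rise in this assay with a 5.4-fold higher number from compound 2 to compound 3 (0.74 log units; beyond the scatter) and, against the best group of the set, a 120-fold higher number from compound 1 to compound 3 (2.06 log units; beyond the scatter) in the same direction. The earlier pair showed a single loss on leaving 2,5-difluorophenyl, whereas both replacements now raise the number beyond the scatter, so among these three compounds the position tolerates neither alternative fluorine pattern and the extra fluorine of compound 3 brings no recovery. No measurement shown here accounts for this order.

The compounds shown leave open how a plain phenyl, a monofluorophenyl or a methoxyphenyl group would compare with the 2,5-difluorophenyl group of compound 1 at this position. They also leave open whether the same order of the three fluorinated groups would hold if the methyl group on the shared core gave way to a cyclopropyl group.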